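Adding a second chloro: notes toward compound 4

The source may report more compounds than this note shows. Statements on the series, on what has been measured and on what is new or still open speak of the compounds shown alone.

Measured compounds:
compound 1, `CCc1ccccc1NC(=O)N[C@H](C)c1ccccc1`, gives 100% in an ADME assay on the whole organism with Oryza sativa as the target, tested at 1 uM; on this read-out lower numbers stand for a stronger effect and higher numbers for a weaker effect at the one concentration tested
compound 2, `C[C@@H](NC(=O)Nc1ccccc1Cl)c1ccccc1`, gives 103% in this assay
compound 3, `C[C@H](NC(=O)Nc1ccccc1Cl)c1ccccc1`, gives 104% in this assay

Compound 2 holds the second highest of the three numbers in this assay; the nearest neighbour is a number 1 percentage points higher from compound 2 to compound 3 (within the scatter), the furthest is a number 3 percentage points higher from compound 1 to compound 2 (within the scatter). Compound 4, `C[C@@H](NC(=O)Nc1c(Cl)cccc1Cl)c1ccccc1`, arises from compound 2 by chloro in place of hydrogen on an aromatic carbon. Of the measured steps, only a number 3 percentage points higher from compound 1 to compound 2 (within the scatter) alters a substituent on that aromatic ring, and it stayed within the scatter; the step of a number 1 percentage points higher from compound 2 to compound 3 (within the scatter) also stayed within the scatter, which follows from the fact that compounds 2 and 3 differ only in the configuration as drawn. All three numbers sit close together, so no step beyond the scatter is expected in this assay; the estimated move is a number 2 percentage points lower from compound 2 to compound 4 (within the scatter). Compound 4 is therefore expected to give 101%, with a range from 92% to 110%.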

Compound 4, a percentage reported as activity, at one concentration (the size of the read-out at that concentration, not a potency): 99%
Beside the measured number, compound 4's estimate is 2 percentage points above it; low and high end bracket the measured number.
By their numbers in this assay, from the lowest: compounds 4, 1, 2 and 3 (each within the scatter of the next).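

Chloro in place of hydrogen at this aromatic carbon, ortho to a large group and meta to a chloro group, gives in this assay a number 4 percentage points lower from compound 2 to compound 4 (within the scatter). The earlier steps shown here changed only the existing substituent or the configuration as drawn, whereas this step shows that the read-out does not separate hydrogen from chloro at this carbon. Nothing at hand gives a reason for this step. Open, from the compounds shown here alone, is whether an amine, a carboxylic acid or a longer chain at this carbon would give a step beyond the scatter.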